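A few compounds are considered here, and "the series" means these few. Any claim that something is new, unique, unknown or untested is made for them only; others in the source may bear on it.

Measured so far in a functional assay on QGY-7703 cells (Homo sapiens) for cytotoxicity, read by MTT assay, with a stated time of 24 h; a higher number here means a weaker inhibitor, a lower number a stronger inhibitor
- compound 1 `O=C1/C(=C/c2ccccc2F)CN(S(=O)(=O)c2ccc(F)cc2)C/C1=C\c1ccccc1F` gives 8500 nM
- compound 2 `O=C1/C(=C/c2cccc([N+](=O)[O-])c2)CN(S(=O)(=O)c2ccc(F)cc2)C/C1=C\c1cccc([N+](=O)[O-])c1` gives 11900 nM

These two values lie within the usual scatter of each other, so compound 2 cannot be told apart from compound 1 on these numbers. Compound 3 `O=C1/C(=C/c2cccc([N+](=O)[O-])c2)CN(S(=O)(=O)c2ccc(F)cc2)C/C1=C\c1ccccc1F` differs from compound 2 in one place: 2-fluorophenyl in place of 3-nitrophenyl on a double-bonded chain carbon bound to a double-bonded ring carbon with 2-fluorophenyl in place of 3-nitrophenyl on a double-bonded chain carbon bound to a double-bonded ring carbon. Among the measured compounds shown here, no measured step shows this change alone. Compound 3 shares one group with compound 1 at 8500 nM and one with compound 2 at 11900 nM so no step beyond the scatter is expected in this assay here. The expected change is a 1.2-fold lower number from compound 2 to compound 3 (0.08 log units; within the scatter) and it stays small. Compound 3 is estimated at 10000 nM with an expected range from 5000 nM to 20000 nM for its measurement.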

Compound 3, half-maximal inhibitory concentration: 14900 nM
The estimate for compound 3 lay 1.5-fold (0.17 log units) below the measured number; low and high end bracket the measured number.
By their numbers in this assay, from the lowest: compounds 1, 2 and 3 (each within the scatter of the next).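

In this assay, 2-fluorophenyl in place of one 3-nitrophenyl gives a 1.3-fold higher number from compound 2 to compound 3 (0.10 log units; within the scatter), and 3-nitrophenyl in place of one 2-fluorophenyl gives a 1.8-fold higher number from compound 1 to compound 3 (0.24 log units; within the scatter). On a double-bonded chain carbon bound to a double-bonded ring carbon, a single exchange in either direction therefore causes no readable shift, and a compound carrying one of each group cannot be told apart from those carrying a matched pair. No measurement here offers an explanation for this. On these data alone, whether an amine, a carboxylic acid or a longer chain at this place would move the number stays open.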